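The compounds below may be only part of what the source reports. "The series", "measured", "known", "first", "only" and "open" are said of these compounds alone.

In a functional assay on T98G cells (Homo sapiens) for inhibition, read by MTT assay, with a stated time of 72 h (a lower number here means a stronger inhibitor, a higher number a weaker inhibitor), three compounds sharing one core have been measured. Compound 1 (`COc1ccc(NC(=S)NC2CC(C)(C)Oc3ccc(Br)cc32)cc1`) gives 33000 nM, compound 2 (`COc1ccccc1NC(=S)NC1CC(C)(C)Oc2ccc(Br)cc21`) gives 42000 nM, and compound 3 (`CC1(C)CC(NC(=S)NCc2ccccc2)c2cc(Br)ccc2O1`) gives 54000 nM. Compound 3 thus stands within the scatter of both others, and the three cannot be ranked. The next compound is compound 4 (`CC1(C)CC(NC(=S)Nc2ccc(Cl)cc2)c2cc(Br)ccc2O1`), which carries 4-chlorophenyl in place of benzyl on an amide-type nitrogen. For the measured compounds named here, two measured steps bear on this change, since both exchange a methoxy-bearing aryl group for benzyl at the same place: a 1.6-fold higher number from compound 1 to compound 3 (0.21 log units; within the scatter), and a 1.3-fold higher number from compound 2 to compound 3 (0.11 log units; within the scatter). Moving the methoxy group gave a similarly small result, a 1.3-fold higher number from compound 1 to compound 2 (0.10 log units; within the scatter). Going by the values given here, no compound with chlorine on this group has been measured, so that part of the change is untested. Because of the small steps of a 1.6-fold higher number from compound 1 to compound 3 (0.21 log units; within the scatter) and a 1.3-fold higher number from compound 2 to compound 3 (0.11 log units; within the scatter), no change beyond the scatter is expected in this assay. The estimated step is a 1.5-fold lower number from compound 3 to compound 4 (0.19 log units; within the scatter). For compound 4 the estimate is 35000 nM, with an expected range from 15000 nM to 70000 nM.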

Compound 4, half-maximal inhibitory concentration: 22000 nM
Beside the measured number, compound 4's estimate is 1.6-fold (0.20 log units) above it, within the range that was stated.
By their numbers in this assay, from the lowest: compounds 4, 1, 2 and 3 (each within the scatter of the next, the first and the last beyond it).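

In this assay, for the compounds shown here, the change from benzyl to 4-chlorophenyl on this amide-type nitrogen gives the first step at this position that lies beyond the scatter, a 2.5-fold lower number from compound 3 to compound 4 (0.39 log units; beyond the scatter), so the group on this nitrogen can alter the number. The other two aryl groups stay unseparated from 4-chlorophenyl, with a 1.9-fold lower number from compound 2 to compound 4 (0.28 log units; within the scatter) for the group carrying methoxy in the 2-position, and a 1.5-fold lower number from compound 1 to compound 4 (0.18 log units; within the scatter) for chloro in place of methoxy on an aromatic carbon, so only benzyl stands apart, and only from compound 4. Nothing measured explains this step.

The compounds shown leave open whether the step follows the chloro group itself or the aromatic ring standing directly on the nitrogen, which an unsubstituted phenyl or a 4-chlorobenzyl group would help separate. Going by these compounds, how a longer chain such as phenethyl or a group carrying an amine would read at this nitrogen also remains open.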